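Three Sulfonamides Measured, a Furan Analogue Awaiting Its Number

The compounds below may be only part of what the source reports. "The series", "measured", "known", "first", "only" and "open" are said of these compounds alone.

compound 1 `N#CC1=C(N)N(c2ccc(S(N)(=O)=O)cc2)C2=C(CCCC2)C1c1ccccc1O`: 40%
compound 2 `N#CC1=C(N)N(c2ccc(S(N)(=O)=O)cc2)C2=C(CCCC2)C1c1ccc([N+](=O)[O-])cc1`: 5%
compound 3 `N#CC1=C(N)N(c2ccc(S(N)(=O)=O)cc2)C2=C(CCCC2)C1c1ccc(Cl)cc1Cl`: 50%

In a functional assay on Ehrlich cells (Mus musculus) for cytotoxicity, read by trypan blue exclusion, with a stated time of 2 h, tested at 25 ug/mL (a lower number here means a weaker effect, a higher number a stronger effect of the compound at the concentration tested), compound 3 stands highest of the three numbers, with compound 1 nearest and compound 2 furthest. The step of a number 10 percentage points higher from compound 1 to compound 3 (within the scatter) lies within the scatter, while a number 45 percentage points higher from compound 2 to compound 3 (beyond the scatter) and a number 35 percentage points lower from compound 1 to compound 2 (beyond the scatter) are large.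

Compound 4 `Cc1ccc(C2C(C#N)=C(N)N(c3ccc(S(N)(=O)=O)cc3)C3=C2CCCC3)o1` differs from compound 3 in one place: 5-methylfuran-2-yl in place of 2,4-dichlorophenyl on a saturated ring carbon. The two steps that change the group on that saturated ring carbon, from compound 1 and from compound 2 to compound 3, both bear on this change, yet one is within the scatter and the other large, and none of them places a 5-methylfuran-2-yl there. Compound 4 is therefore expected to show a step of a number 15 percentage points lower from compound 3 to compound 4 (beyond the scatter) in this assay, with wide uncertainty. The estimate for compound 4 is 35%, between 10% and 60%.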

Compound 4, a percentage reported as activity, at one concentration (the size of the read-out at that concentration, not a potency): 10%
The estimate for compound 4 lay 25 percentage points above the measured number, and the stated range covers the measured number.
By their numbers in this assay, from the lowest: compounds 2 and 4 (each within the scatter of the next); then compounds 1 and 3 (each within the scatter of the next).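

Putting 5-methylfuran-2-yl on the saturated ring carbon gives (a number 40 percentage points lower from compound 3 to compound 4 (beyond the scatter)) and (a number 30 percentage points lower from compound 1 to compound 4 (beyond the scatter)) in this assay but only (a number 5 percentage points higher from compound 2 to compound 4 (within the scatter)). The group thus stands with 4-nitrophenyl, and the four compounds fall into two pairs: compounds 2 and 4 against compounds 1 and 3. Nothing available explains this division.

On these data alone, whether furan-2-yl without the methyl, or thiophen-2-yl, would join the first pair or the second remains open. So does the effect of replacing the cyano group with a carboxylic acid.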